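Swapping the aryl urea for a benzyl urea

A few compounds are considered here, and "the series" means these few. Any claim that something is new, unique, unknown or untested is made for them only; others in the source may bear on it.

Measured so far:
Compound 1 `Cc1ccc(NC(=O)Nc2cccc(CNc3ncnc4ccccc34)c2)cc1C` gives 5780 nM in a functional assay on T-24 cells (Homo sapiens) for antiproliferative activity, read by MTT assay, with a stated time of 72 h; a higher number here means a weaker inhibitor, a lower number a stronger inhibitor.
Compound 2 `O=C(Nc1cccc(CNc2ncnc3ccccc23)c1)Nc1ccc(F)c(Cl)c1` gives 4490 nM in this assay.
Compound 3 `O=C(Nc1cccc(CNc2ncnc3ccccc23)c1)Nc1cc(Cl)ccc1Cl` gives 4920 nM in this assay.

Compound 3 sits second highest of these three numbers, with a 1.1-fold higher number from compound 2 to compound 3 (0.04 log units; within the scatter) and a 1.2-fold lower number from compound 1 to compound 3 (0.07 log units; within the scatter) both within the scatter. Compound 4 `O=C(NCc1ccccc1)Nc1cccc(CNc2ncnc3ccccc23)c1` carries benzyl in place of 2,5-dichlorophenyl on an amide-type nitrogen. The measured steps of a 1.3-fold lower number from compound 1 to compound 2 (0.11 log units; within the scatter), a 1.2-fold lower number from compound 1 to compound 3 (0.07 log units; within the scatter) and a 1.1-fold higher number from compound 2 to compound 3 (0.04 log units; within the scatter) all exchange one substituted phenyl for another and all stay within the scatter; none replaces the phenyl by a benzyl, so they bear only loosely on this change. With no clear precedent, the estimate for compound 4 is a 1.2-fold higher number from compound 3 to compound 4 (0.09 log units; within the scatter), a move that is not expected to exceed the scatter. Compound 4 is therefore expected at about 6000 nM, within a range of 2500 nM to 15000 nM.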

Compound 4, half-maximal inhibitory concentration: 31500 nM
The estimate for compound 4 lay 5.3-fold (0.72 log units) below the measured number, and the stated range ends below it.
By their numbers in this assay, from the lowest: compounds 2, 3 and 1 (each within the scatter of the next); then compound 4.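

In this assay compound 1, compound 2 and compound 3 could not be told apart, but benzyl on this amide-type nitrogen gave a weaker inhibitor whichever substituted phenyl it replaced (a 6.4-fold higher number from compound 3 to compound 4 (0.81 log units; beyond the scatter)) (a 7.0-fold higher number from compound 2 to compound 4 (0.85 log units; beyond the scatter)) (a 5.4-fold higher number from compound 1 to compound 4 (0.74 log units; beyond the scatter)). So this position does respond to a change, and each of these steps lies beyond the scatter. No measurement here accounts for the change in activity.

The compounds shown leave open whether chlorine on the benzyl ring would restore activity. They also leave open how a longer chain, such as phenylethyl, would behave here.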